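Sulfonamide to benzamide swap on the trimethoxyphenyl series

The source may report more compounds than this note shows. Statements on the series, on what has been measured and on what is new or still open speak of the compounds shown alone.

Measured so far:
- compound 1 `COc1cc(N(Cc2ccccc2)S(=O)(=O)c2ccc(C)cc2)cc(OC)c1OC`: 7810 nM
- compound 2 `COc1cc(N(Cc2nc3ccccc3[nH]2)S(=O)(=O)c2ccc(Br)cc2)cc(OC)c1OC`: 6890 nM
- compound 3 `COc1cc(N(Cc2nc3ccccc3[nH]2)S(=O)(=O)c2ccc(C(C)(C)C)cc2)cc(OC)c1OC`: 29800 nM

In a functional assay on PC-3 cells (Homo sapiens) for inhibition, read by MTT assay, with a stated time of 48 h (a higher number here means a weaker inhibitor, a lower number a stronger inhibitor), compound 2 gives the lowest of the three numbers, yet compound 1 sits within the scatter of it, so no order between those two can be claimed. Only compound 3 stands clearly apart: a 4.3-fold higher number from compound 2 to compound 3 (0.64 log units; beyond the scatter).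

Compound 4 `COc1cc(N(Cc2nc3ccccc3[nH]2)C(=O)c2cccc(Cl)c2)cc(OC)c1OC` has not been measured. Relative to compound 2 the change is (3-chlorophenyl)carbonyl in place of (4-bromophenyl)sulfonyl on a nitrogen on an aromatic ring. Going by the values given here, the single measured step that touches the same region of the molecule is the one from compound 2 to compound 3, a change on the aryl ring that stays attached through sulfur. Nothing measured here exchanges the sulfonyl link for a carbonyl, so the step from compound 2 to compound 4 in this assay cannot be read off a precedent; a modest move in either direction, or none beyond the scatter, is all the data allow. The expected step is a 1.3-fold higher number from compound 2 to compound 4 (0.12 log units; within the scatter). Compound 4 is estimated at 9000 nM, within 2500 nM to 35000 nM.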

Compound 4, half-maximal inhibitory concentration: > 50000 nM
Compound 4 gave a limit, no number; the forecaster's own chance of this, stated with the estimate: 10%; middle value at least 5.5-fold (0.74 log units) away from the limit.
By their numbers in this assay, from the lowest: compounds 2 and 1 (each within the scatter of the next); then compound 3. At a limit, above all of these: compound 4.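

In this assay, the step to (3-chlorophenyl)carbonyl in place of (4-bromophenyl)sulfonyl on the nitrogen gives an at least 7.2-fold higher number from compound 2 to compound 4 (0.86 log units; beyond the scatter), the first sign that this position is sensitive to a change of the link itself. The reading for compound 4 is a limit, not a number: the limit of > 50000 nM in this assay, at which 1 of the 4 values shown sits. The earlier comparison varied only the substituent on the aryl ring held through sulfur, with a 4.3-fold higher number from compound 2 to compound 3 (0.64 log units; beyond the scatter), whereas here the link and the ring substitution change together, so the step cannot be assigned to either alone.

From the compounds shown here alone, a (4-bromophenyl)carbonyl group on the same nitrogen would separate the link from the ring substitution, and that comparison remains open. Also open, going by these compounds, is whether an amine or a carboxylic acid on the aryl ring of the carbonyl series would give a measurable number.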